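This account rests on a few compounds, and the source may have more. Where it says the series, first, only, none or still open, it means among the compounds named here.

Two compounds share one core and differ only in the group attached to the carbonyl carbon on the ring nitrogen. In a functional assay on isolated protein for inhibition of Glucose-dependent insulinotropic receptor (Rattus norvegicus), read by HTRF and cAMP accumulation (on this read-out lower numbers stand for an effect already at smaller amounts and higher numbers for an effect only at larger amounts of compound), compound 1 `Cc1nc(S(C)(=O)=O)ccc1Oc1ncnc(OC2CCN(C(=O)O[C@@H](C)C(F)(F)F)CC2)c1F` gives 109 nM. Compound 2 `Cc1nc(S(C)(=O)=O)ccc1Oc1ncnc(OC2CCN(C(=O)C3(F)CCC3)CC2)c1F` gives 123 nM in this assay. Of these two numbers, compound 2 has the higher one, but the step of a 1.1-fold higher number from compound 1 to compound 2 (0.05 log units; within the scatter) is too small to count as a real difference. Compound 3 `Cc1nc(S(C)(=O)=O)ccc1Oc1ncnc(OC2CCN(C(=O)c3ncc(Cl)cn3)CC2)c1F` keeps the same core and changes the same place once more: a group of 7 heavy atoms (4 carbon, 2 nitrogen, 1 chlorine; one six-membered aromatic ring with 2 hetero atoms) in place of a group of 5 heavy atoms (4 carbon, 1 fluorine; one four-membered non-aromatic ring of carbon only), on a carbonyl carbon. Going by the values given here, only one measured step bears on this spot, the step of a 1.1-fold higher number from compound 1 to compound 2 (0.05 log units; within the scatter), which shows that exchanging one carbonyl substituent for a quite different one left the read-out essentially where it was. The new group is again of a different kind, and nothing measured speaks for or against a shift in either direction, so the expected step of a 1.1-fold higher number from compound 2 to compound 3 (0.02 log units; within the scatter) from compound 2 to compound 3 is none beyond the scatter. Among the compounds with values here, for compound 3 the expected value in this assay is therefore 130 nM, with a range from 45 nM to 380 nM, widened because the step of a 1.1-fold higher number from compound 1 to compound 2 (0.05 log units; within the scatter) is the only guide.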

Compound 3, half-maximal effective concentration: 30.9 nM
Compound 3: middle estimate off by 4.2-fold (0.62 log units), on the high side, and the stated range ends above it.
By their numbers in this assay, from the lowest: compound 3; then compounds 1 and 2 (each within the scatter of the next).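

The earlier pair suggested that the group on the carbonyl carbon might hardly matter, but in this assay the 5-chloropyrimidin-2-yl group gives a 4.0-fold lower number from compound 2 to compound 3 (0.60 log units; beyond the scatter) and, against the other earlier compound, a 3.5-fold lower number from compound 1 to compound 3 (0.55 log units; beyond the scatter) as well. Both steps lie beyond the scatter, so this position does respond to what is attached, even though the two earlier groups, one with a four-membered carbon ring and one with no ring, could not be told apart. Compound 3, the only one of the three with an aromatic ring at this place, now has the lowest number, but no measurement is available that would account for the step.

The compounds shown do not separate the share of the aromatic ring from that of the chlorine, which a pyrimidin-2-yl group without the chlorine or a plain phenyl group on the same carbonyl carbon could help to settle. Going by these compounds, it also remains open whether a larger change of the ring, such as a pyridine or a thiazole in place of the pyrimidine, would move the number further in the same direction or back again.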